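From dimethylamino to diethylamino: compound 1 and compound 4

The compounds below may be only part of what the source reports. "The series", "measured", "known", "first", "only" and "open" are said of these compounds alone.

Compound 1 `CN(C)c1ccc2nc(-c3cccc4ccccc34)[nH]c(=O)c2c1` gives 50 nM
Compound 2 `CCN(CC)c1ccc2nc(-c3ccccc3OC(F)(F)F)[nH]c(=O)c2c1` gives 40 nM
Compound 3 `Cc1ccc2nc(-c3cccc(OC(F)(F)F)c3)[nH]c(=O)c2c1` gives > 50000 nM

For the measured compounds named here, in a functional assay on HeLa cells (Homo sapiens) for cytotoxicity, read by MTT assay, with a stated time of 2 days (on this read-out lower numbers stand for stronger inhibition and higher numbers for weaker inhibition), compound 1 at 50 nM and compound 2 at 40 nM lie within the scatter of each other, and these are the only two true numbers. For compound 3 the entry > 50000 nM is a limit of the assay.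

Compound 4 `CCN(CC)c1ccc2nc(-c3cccc4ccccc34)[nH]c(=O)c2c1` differs from compound 1 by diethylamino in place of dimethylamino on an aromatic carbon. In this assay no change beyond the scatter is expected, because compound 2 with diethylamino gives 40 nM. The expected step is a 1.1-fold lower number from compound 1 to compound 4 (0.05 log units; within the scatter). Compound 4 is estimated at 45 nM, with an expected range from 15 nM to 150 nM.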

Compound 4, half-maximal inhibitory concentration: 4 nM
Compound 4: the middle estimate sits 11-fold (1.05 log units) above what was measured; measured number below the stated range.
By their numbers in this assay, from the lowest: compound 4; then compounds 2 and 1 (each within the scatter of the next). At a limit, above all of these: compound 3.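

In this assay the change to diethylamino on this aromatic carbon, with nothing else altered, gives a 13-fold lower number from compound 1 to compound 4 (1.10 log units; beyond the scatter) and so lies beyond the scatter. For the compounds shown here, this is the first direct reading at this position, and it shows that the position is not indifferent to the alkyl groups on its nitrogen. Nothing measured here accounts for the size of this step. On these data alone, whether a longer chain such as dipropylamino or a ring amine such as pyrrolidine would go further in the same direction remains open.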